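Adding a methyl to the pyrazine of a Boc-protected analogue

A few compounds are considered here, and "the series" means these few. Any claim that something is new, unique, unknown or untested is made for them only; others in the source may bear on it.

Measured so far in a functional assay on PANC-1 cells (Homo sapiens) for inhibition, read by MTT assay, with a stated time of 72 h; a higher number here means a weaker inhibitor, a lower number a stronger inhibitor:
compound 1 `COc1cc(NC(=O)c2cnc(C)cn2)c2ncccc2c1`: 800 nM
compound 2 `CC(C)(C)OC(=O)NCCOc1cc(NC(=O)c2cnccn2)c2ncccc2c1`: 9500 nM
compound 3 `NCCOc1cc(NC(=O)c2cnccn2)c2ncccc2c1`: a limit

Compound 1 carries a methyl on its pyrazine and a methoxy on the shared core, and in this assay compound 1 gives 800 nM. Compound 2 lacks that methyl and instead carries a tert-butoxycarbonyl-protected aminoethoxy chain; in this assay compound 2 gives 9500 nM, the higher of the two numbers, with the gap to compound 1 lying beyond the usual scatter. For compound 3 this assay reports only a limit, > 10000 nM. Among the measured compounds shown here, the one measured single step, an at least 1.0-fold higher number from compound 2 to compound 3 (0.02 log units; that floor lies within the scatter), rests on that limit (the limit of > 10000 nM in this assay, at which 1 of the 3 values shown sits) and concerns the amine, not the pyrazine.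

Compound 4 `Cc1cnc(C(=O)Nc2cc(OCCNC(=O)OC(C)(C)C)cc3cccnc23)cn1` takes compound 2 and makes one change: methyl in place of hydrogen on an aromatic carbon. For the measured compounds named here, no measured step bears on this change directly, since compound 1 differs from compound 2 in two places at once. The estimate for compound 4 is therefore a guarded one, a step of a 1.9-fold lower number from compound 2 to compound 4 (0.28 log units; within the scatter) towards a lower number. Compound 4 is expected to give about 5000 nM, somewhere between 1500 nM and 15000 nM.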

Compound 4, half-maximal inhibitory concentration: 2170 nM
Compound 4: the middle estimate sits 2.3-fold (0.36 log units) above what was measured; low and high end bracket the measured number.
By their numbers in this assay, from the lowest: compound 1; then compound 4; then compound 2. At a limit, above all of these: compound 3.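

In this assay the change from pyrazin-2-yl to 5-methylpyrazin-2-yl can now be read on its own, with the chain unchanged: a 4.4-fold lower number from compound 2 to compound 4 (0.64 log units; beyond the scatter). With the 5-methylpyrazin-2-yl group held in place, the chain can be read alone as well, and putting the ((tert-butoxycarbonyl)amino)methyl group onto the methoxy gives a 2.7-fold higher number from compound 1 to compound 4 (0.43 log units; beyond the scatter). Nothing measured in the compounds shown says why the added methyl lowers the number.

From the compounds shown here alone, whether an ethyl, a chlorine or an amine in the same place on the pyrazine would lower the number further remains open. Going by these compounds, compound 3 gives only a limit, > 10000 nM, and the effect of this methyl on a compound carrying that free amine also remains open.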